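The source may report more compounds than this note shows. Statements on the series, on what has been measured and on what is new or still open speak of the compounds shown alone.

Compound 1 `COc1cc(C(=O)/C=C/c2ccc(OCCCC(=O)NCCCNCCCCN)cc2)cc(OC)c1OC` and compound 2 `COc1cc(C(=O)/C=C/c2ccc(OCCCC(=O)NCCCCNCCCN)cc2)cc(OC)c1OC` are the measured compounds. In a functional assay on PC-3 cells (Homo sapiens) for antiproliferative activity, read by MTT assay, with a stated time of 48 h (on this read-out lower numbers stand for stronger inhibition and higher numbers for weaker inhibition), compound 1 gives only a limit of the assay, > 100000 nM (the limit of > 100000 nM in this assay, at which 1 of the 2 values shown sits). In this assay compound 2 gives 79300 nM. Compound 1 therefore stands on a bound, not a number. Compound 3 `COc1cc(C(=O)/C=C/c2ccc(OCCCC(=O)NCCCNCCCCNCCN)cc2)cc(OC)c1OC` is not yet measured; it differs from compound 1 by 2-aminoethyl in place of hydrogen on an amine nitrogen. Within the data shown here, the only measured step, an at least 1.2-fold lower number from compound 1 to compound 2 (0.10 log units; that floor lies within the scatter), rearranges the chain rather than lengthening it and stays within the scatter. Among the measured compounds shown here, no measured step bears on the added group, so no change beyond the scatter is expected. Compound 3 is expected to give 85000 nM, between 40000 nM and 200000 nM. That expectation means a step of an at least 1.1-fold lower number from compound 1 to compound 3 (0.07 log units; that floor lies within the scatter).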

Compound 3, half-maximal inhibitory concentration in the PC-3 assay: 34000 nM
Estimate against measurement, compound 3: 2.5-fold (0.40 log units) above; the whole stated range lies above it.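

Among these compounds, in the PC-3 assay, 2-aminoethyl on the amine nitrogen gives the first changes beyond the scatter: an at least 2.9-fold lower number from compound 1 to compound 3 (0.46 log units; beyond the scatter), and a 2.3-fold lower number from compound 2 to compound 3 (0.37 log units; beyond the scatter). Compound 1 stands only on a limit of the assay, so its step is a floor: the limit of > 100000 nM in the PC-3 assay, at which 1 of the 3 values shown sits. In a physicochemical assay for lipophilicity, read by spectrophotometry, measured as octanol-water partition, tested at 300 uM (a lower number here means a more polar compound, a higher number a more lipophilic compound), compound 1 gives -1.43 and compound 3 gives -1.98, the lower number.

Going by these compounds, whether the stronger inhibition in the PC-3 assay is tied to that lower partition number stays open. So does the effect of a longer chain on this nitrogen, such as 3-aminopropyl, or of a hydroxyl replacing the end amine.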